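A Ring With a Hydroxyl in Place of a Short Chain

The source may hold more compounds than are shown below. What is called first, only, known or untested is meant among the compounds shown, and "the series" means these compounds.

Compound 3, with the structure `CCCNCC(=O)N1N=C(c2cc3ccccc3oc2=O)CC1c1ccccc1`, was tested in a functional assay on MGC-803 cells (Homo sapiens) for cytotoxicity, read by MTT assay, with a stated time of 48 h (on this read-out higher numbers stand for weaker inhibition and lower numbers for stronger inhibition), and gave 4880 nM. Among the three compounds measured so far it gives the second highest number. Compound 2, `CC1=NN(C(=O)CN2CCCCC2)C(c2ccccc2O)C1`, gives 4310 nM, a difference from compound 3 that stays within the usual scatter of the measurement. Compound 1, `CCC(=O)N1N=C(C)CC1c1cc(Br)cc(Br)c1O`, gives 38600 nM, a much higher number than compound 3, and that gap lies beyond the scatter.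

Compound 4, `O=C(CN1CCC(O)CC1)N1N=C(c2cc3ccccc3oc2=O)CC1c1ccccc1`, has not yet been measured. It differs from compound 3 in one place: 4-hydroxypiperidin-1-yl in place of propylamino on a saturated chain carbon bound to a carbonyl carbon. Among the compounds with values here, no measured pair shows this particular change on this core, so there is no step to lean on. Compound 2 carries a related six-membered ring at the same kind of position on a different core, and its value sits close to that of compound 3; this gives no reason to expect a large move. The estimate for compound 4 is therefore a step of a 1.2-fold lower number from compound 3 to compound 4 (0.09 log units; within the scatter), not beyond the scatter. Compound 4 is expected to give about 4000 nM, within a range from 1500 nM to 12000 nM.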

Compound 4, half-maximal inhibitory concentration: "not active" (no number reported)
Compound 4: no number reported, and the estimate cannot be compared.
By their numbers in this assay, from the lowest: compounds 2 and 3 (each within the scatter of the next); then compound 1.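

In this assay, within the data shown here, compound 4 is reported as "not active" without a number, so no step between compound 3 and compound 4 can be read. On these data alone, how far 4-hydroxypiperidin-1-yl in place of propylamino shifts the number on this core stays open. Nothing shown speaks to a cause.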